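The compounds below may be only part of what the source reports. "The series", "measured", "known", "first", "only" and "open" are said of these compounds alone.

Compound 1 `C=C1[C@H](OCC(C)C)C[C@@H](OC(=O)c2cccnc2)C(C)(C)/C=C/[C@@H](C)C(=O)[C@@]2(OC(C)=O)C[C@H](C)[C@H](OC(C)=O)[C@@H]2[C@H]1OC(C)=O`: 4.5%
Compound 2 `C=C1[C@H](OCC(C)C)C[C@@H](OC(=O)c2cccnc2)C(C)(C)/C=C/[C@@H](C)C(=O)[C@@]2(OC(C)=O)C[C@@](C)(OC(C)=O)[C@H](OC(C)=O)[C@@H]2[C@H]1OC(C)=O`: 1.1%

Both compounds were tested in a functional assay on HeLa cells (Homo sapiens) for inhibition, read by MTT assay, with a stated time of 72 h, tested at 30 ug/mL; on this read-out higher numbers stand for more inhibition of growth at the one concentration tested and lower numbers for less inhibition of growth. Compound 2 gives 1.1% and compound 1 gives 4.5%. These two values lie within the usual scatter of each other, so they cannot be ranked. Both sit close to the bottom of the scale, which means that compound 2 shows very little inhibition of growth at the one concentration tested.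

Compound 3 `C=C1[C@H](OC(C)=O)C[C@@H](OC(=O)c2cccnc2)C(C)(C)/C=C/[C@@H](C)C(=O)[C@@]2(OC(C)=O)C[C@@](C)(OC(C)=O)[C@H](OC(C)=O)[C@@H]2[C@H]1OC(C)=O` has not yet been measured. It differs from compound 2 in one place: acetyl in place of isobutyl on an oxygen on a saturated carbon. The change thus turns isobutoxy into acetoxy.

Going by the values given here, no measured pair shows this change on its own, so the data give no direct guide to its effect. Among the compounds with values here, the only basis is that compound 2 at 1.1% and compound 1 at 4.5% are both low. No step beyond the scatter is therefore expected in this assay, and any expected drift is slightly upward, since the values start so near the bottom. The estimated change is a number 2.9 percentage points higher from compound 2 to compound 3 (within the scatter). The estimate for compound 3 is 4%, with an expected range from 0% to 14%.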

Compound 3, percent growth inhibition at one concentration: 17.9%
Estimate against measurement, compound 3: 13.9 percentage points below; measured number outside the range, above it.
By their numbers in this assay, from the lowest: compounds 2 and 1 (each within the scatter of the next); then compound 3.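

Putting acetyl in place of isobutyl on this oxygen on a saturated carbon leads in this assay to a number 16.8 percentage points higher from compound 2 to compound 3 (beyond the scatter). This shows that the position is not silent: the group carried on this oxygen can alter how much growth is inhibited, which compounds 1 and 2 could not show, as both carry isobutoxy here. Nothing available explains why the change has this effect.

As far as these compounds go, a single step cannot tell whether the higher number comes from the presence of acetyl or the absence of isobutyl, so it remains open how a free hydroxyl, a longer ester such as butanoyl, or an amine at this place would behave in this assay. From the compounds shown here alone, it also remains open whether the same swap would raise the number on the core of compound 1, and whether compound 3, at 17.9% at the one concentration tested, would inhibit growth to a greater extent at higher concentrations.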